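The compounds below may be only part of what the source reports. "The series", "measured", "known", "first", "only" and "open" are said of these compounds alone.

Measured compounds in an ADME assay on the whole organism (plasma) for pharmacokinetics, with Rattus norvegicus as the target, with a stated time of 6 h, at a dose of 10 mg/kg by the oral route; a higher number here means more compound in the circulation at the dose given, a lower number less compound in the circulation:

compound 1, `CCNc1nc(C)c(-c2nc3ccccc3s2)c(N[C@@H]2C[C@H](CO)[C@@H](O)[C@H]2O)n1`: 2580 ng.h/mL
compound 2, `Cc1nc(NC(C)C)nc(N[C@@H]2C[C@H](CO)[C@@H](O)[C@H]2O)c1-c1nc2ccccc2s1`: 8420 ng.h/mL
compound 3, `CCOC(=O)NCCNc1nc(C)c(-c2nc3ccccc3s2)c(N[C@@H]2C[C@H](CO)[C@@H](O)[C@H]2O)n1`: 151 ng.h/mL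

Compound 2 stands highest of the three in this assay. Its nearest neighbour is compound 1, reached by a 3.3-fold higher number from compound 1 to compound 2 (0.51 log units; beyond the scatter); its furthest is compound 3, reached by a 56-fold lower number from compound 2 to compound 3 (1.75 log units; beyond the scatter). Compound 1 and compound 3 are joined by a 17-fold lower number from compound 1 to compound 3 (1.23 log units; beyond the scatter).

The step to compound 4, `Cc1nc(NCc2ccccc2)nc(N[C@@H]2C[C@H](CO)[C@@H](O)[C@H]2O)c1-c1nc2ccccc2s1`, changes the same position on the shared core: benzyl in place of isopropyl on a nitrogen on an aromatic ring.

For the measured compounds named here, two measured steps touch this position. Methyl in place of hydrogen on the saturated chain carbon bound to the nitrogen gave a 3.3-fold higher number from compound 1 to compound 2 (0.51 log units; beyond the scatter), a modest rise. Replacing isopropyl by 2-((ethoxycarbonyl)amino)ethyl gave a 56-fold lower number from compound 2 to compound 3 (1.75 log units; beyond the scatter), a large fall. Going by the values given here, neither step introduces a six-membered aromatic ring of carbon only, so no measured step directly models benzyl; the series only shows that larger groups here have moved the number down. A modest fall in this assay is therefore expected, not a large one. Compound 4 is expected at 3500 ng.h/mL, with a range of 1000 ng.h/mL to 12000 ng.h/mL. This corresponds to an expected step of a 2.4-fold lower number from compound 2 to compound 4 (0.38 log units; beyond the scatter).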

Compound 4, area under the concentration-time curve: 1050 ng.h/mL
Beside the measured number, compound 4's estimate is 3.3-fold (0.52 log units) above it; the measured number falls inside the stated range.
By their numbers in this assay, from the lowest: compound 3; then compound 4; then compound 1; then compound 2.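

In this assay, for the compounds shown here, benzyl in place of isopropyl gives an 8.0-fold lower number from compound 2 to compound 4 (0.90 log units; beyond the scatter) and is the first measured change at this position to put in a six-membered aromatic ring of carbon only. Read from the ethylamino side, phenyl in place of methyl gives a 2.5-fold lower number from compound 1 to compound 4 (0.39 log units; beyond the scatter), so compound 4 stands under both compound 1 and compound 2, while phenyl in place of ((ethoxycarbonyl)amino)methyl gives a 7.0-fold higher number from compound 3 to compound 4 (0.84 log units; beyond the scatter) and leaves compound 3 the lowest of the four. The size of the fall therefore depends on which group enters, and no measurement on hand accounts for these differences.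

Still open, from the compounds shown here alone, is whether the fall follows the aromatic ring itself or the larger group, which a saturated cyclohexylmethyl group would help separate. A phenethyl group, a longer chain, or a chain ending in an amine or a carboxylic acid could also show how far this trend extends.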